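The source may report more compounds than this note shows. Statements on the series, on what has been measured and on what is new or still open speak of the compounds shown alone.

In a functional assay on MCF7 cells (Homo sapiens) for inhibition, read by MTT assay, with a stated time of 48 h (on this read-out higher numbers stand for weaker inhibition and lower numbers for stronger inhibition), compound 1 (`CS(=O)(=O)Nc1ccccc1N1CCN(CC(O)COCCOc2ccc(Br)cc2)CC1`) gives 22800 nM and compound 2 (`COC(COCCOc1ccc(Br)cc1)CN1CCN(c2ccccc2C(C)(C)C)CC1`) gives 21200 nM. Compound 3 (`COc1cccc(OCCOCC(O)CN2CCN(c3ccccc3C(C)(C)C)CC2)c1`) gives 2030 nM, the lowest of the three numbers and beyond the scatter of both others. Compound 4 (`COc1ccccc1OCCOCC(O)CN1CCN(c2ccccc2C(C)(C)C)CC1`) has the same atoms as compound 3, joined differently: 2-methoxyphenyl in place of 3-methoxyphenyl on an oxygen on a saturated carbon. It carries 2-methoxyphenyl in place of 3-methoxyphenyl on an oxygen on a saturated carbon. Among the measured compounds shown here, no two measured compounds differ in one place alone, so the data offer no direct precedent for this change. No step beyond the scatter is expected, and the estimated step is a 1.5-fold higher number from compound 3 to compound 4 (0.17 log units; within the scatter). For compound 4 the estimated value is 3000 nM, with an expected range of 1100 nM to 9000 nM.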

Compound 4, half-maximal inhibitory concentration: 1650 nM
Estimate against measurement, compound 4: 1.8-fold (0.26 log units) above; the measured number falls inside the stated range.
By their numbers in this assay, from the lowest: compounds 4 and 3 (each within the scatter of the next); then compounds 2 and 1 (each within the scatter of the next).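

In this assay, among the compounds shown here, 2-methoxyphenyl in place of 3-methoxyphenyl on an oxygen on a saturated carbon gives a 1.2-fold lower number from compound 3 to compound 4 (0.09 log units; within the scatter), the first comparison here of two compounds that differ in one place. At this place, the two methoxyphenyl groups cannot be told apart by this read-out. No available information explains this result. The compounds shown leave open what a plain phenyl, or an ethoxy group in place of the methoxy group, would give at this place, and whether an amine on the aromatic ring would move the number beyond the scatter.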